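The source may hold more compounds than are shown below. What is called first, only, known or untested is meant among the compounds shown, and "the series" means these compounds.

The series shares a single core, a five-membered aromatic ring with two nitrogens carrying an iodo group and a sugar, and varies the substituent on the remaining aromatic carbon. Compound 1 `COC(=O)c1nn([C@@H]2O[C@H](CO)[C@@H](O)[C@H]2O)cc1I` carries a methoxycarbonyl group there, and in a functional assay on CCRF-SB cells (Homo sapiens) (on this read-out higher numbers stand for weaker inhibition and lower numbers for stronger inhibition), compound 1 gives 900 nM, the lowest of the two numbers obtained so far. Within the data shown here, compound 3 `CCCCOC(=O)c1nn([C@@H]2O[C@H](CO)[C@@H](O)[C@H]2O)cc1I` lengthens the ester, and in this assay compound 3 gives 21000 nM; the step of a 23-fold higher number from compound 1 to compound 3 (1.37 log units; beyond the scatter) is the only single-point change measured. Compound 2 `C#Cc1cn([C@@H]2O[C@H](CO)[C@@H](O)[C@H]2O)nc1C(N)=O` differs in two places at once, and in this assay compound 2 reaches only a limit, > 300000 nM, the point described by the limit of > 300000 nM in this assay, at which 1 of the 3 values shown sits.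

Compound 4 `Cc1noc(-c2nn([C@@H]3O[C@H](CO)[C@@H](O)[C@H]3O)cc2I)n1` is the unmeasured member: 3-methyl-1,2,4-oxadiazol-5-yl in place of methoxycarbonyl on an aromatic carbon. Among the measured compounds shown here, no measured step bears directly on exchanging the ester for a ring; the one step that is known, from compound 1 to compound 3, shows that adding bulk at this position costs potency in this assay. The entering group is larger than the one it replaces, so a loss is expected, though smaller than that seen with the butyl ester. The expected step is a 3.3-fold higher number from compound 1 to compound 4 (0.52 log units; beyond the scatter), giving compound 4 an estimated 3000 nM, in the range 600 nM to 15000 nM, with a modest chance that only a limit is returned.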

Compound 4, half-maximal inhibitory concentration: 2800 nM
Compound 4: middle estimate off by 1.1-fold (0.03 log units), on the high side, within the range that was stated.
By their numbers in this assay, from the lowest: compound 1; then compound 4; then compound 3. At a limit, above all of these: compound 2.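

Up to this point the position had been probed only with esters, and compound 4 shows in this assay that the ester can be given up altogether: 3-methyl-1,2,4-oxadiazol-5-yl takes the place of methoxycarbonyl at a modest cost (a 3.1-fold higher number from compound 1 to compound 4 (0.49 log units; beyond the scatter)). Set against the butyl ester, the same ring comes out clearly ahead (a 7.5-fold lower number from compound 3 to compound 4 (0.88 log units; beyond the scatter)), so an entering group larger than methoxycarbonyl need not cost as much as butoxycarbonyl does, although methoxycarbonyl in compound 1 still gives the lowest number of these three compounds. No measurement shown gives a reason for either step.

From the compounds shown here alone, it remains open whether a carboxylic acid, a nitrile, or an oxadiazole with a longer chain in place of its methyl would, on the same core with the iodo group kept, stand nearer to compound 1 or to compound 3. Compound 2 reaches only a limit (> 300000 nM) and differs in two places at once, so it cannot separate the effect of its amide from that of the group replacing the iodo group.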